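The source may report more compounds than this note shows. Statements on the series, on what has been measured and on what is new or still open speak of the compounds shown alone.

Working notes on the quinoline thiosemicarbazone series. Among the measured compounds shown here, compound 1 `S=C(N/N=C/c1ccc2ccccc2n1)Nc1cccc(Br)c1` gives 78600 nM in a functional assay on SGC-7901 cells (Homo sapiens) for antiproliferative activity, read by sulforhodamine B assay, with a stated time of 72 h (on this read-out higher numbers stand for weaker inhibition and lower numbers for stronger inhibition), the higher of the two numbers measured so far. Compound 3 `CC(C)c1cccc(C(C)C)c1NC(=S)N/N=C/c1ccc2ccccc2n1` gives 23500 nM in this assay, and the gap between compound 3 and compound 1 lies beyond the scatter. Compound 2 `Cc1ccc(NC(=O)N/N=C/c2ccc3ccccc3n2)cc1` gives only a limit of the assay, > 100000 nM, in this assay; the limit of > 100000 nM in this assay, at which 1 of the 3 values shown sits, marks where it sits. Compound 4 `S=C(N/N=C/c1ccc2ccccc2n1)Nc1ccccc1` is the next member to be measured. Its relation to compound 1 is hydrogen in place of bromo on an aromatic carbon. For the measured compounds named here, no measured pair shows this change, so no step size is known; the expectation in this assay is a step within the scatter, if anything toward a higher number. The step from compound 1 to compound 4 expected is a 1.2-fold higher number from compound 1 to compound 4 (0.08 log units; within the scatter). Compound 4 is estimated at 95000 nM, with a range from 35000 nM to 250000 nM.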

Compound 4, half-maximal inhibitory concentration: 26500 nM
For compound 4 the middle estimate is 3.6-fold (0.55 log units) above the measured one; measured number below the stated range.
By their numbers in this assay, from the lowest: compounds 3 and 4 (each within the scatter of the next); then compound 1. At a limit, above all of these: compound 2.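

In this assay, among the compounds shown here, hydrogen in place of bromo on an aromatic carbon gives a 3.0-fold lower number from compound 1 to compound 4 (0.47 log units; beyond the scatter), the first step that changes only one place. The bromo group, meta to a large group, is therefore not required for the activity of compound 1, and the plain phenyl of compound 4 gives the lower number. Nothing at hand accounts for the size of this step.

On these data alone, whether an amine or a carboxylic acid at this place would move the number in the same direction stays open. Also open, as far as these compounds go, is whether the step holds elsewhere on the phenyl ring.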